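Removing the oxan-2-yl group from the side chain of compound 2

The source may report more compounds than this note shows. Statements on the series, on what has been measured and on what is new or still open speak of the compounds shown alone.

Measured in a functional assay on the whole organism (strain Wistar albino) for inhibition, with Rattus norvegicus as the target, read by paw edema, with stated times of 30 min and 3 h, at a dose of 10 mg/kg by the oral route; on this read-out higher numbers stand for more inhibition at the one dose given (going by the name of the read-out) and lower numbers for less inhibition:
compound 1 `COc1ccc(F)cc1-c1cccc(-c2nn(CCCC#N)c(=O)o2)c1` — 85%
compound 2 `COc1ccc(F)cc1-c1cccc(-c2nn(CCOC3CCCCO3)c(=O)o2)c1` — 65%

Compound 2 stands lowest of the two numbers in this assay. Compound 1 stands higher by a number 20 percentage points lower from compound 1 to compound 2 (beyond the scatter), read backwards. Compound 3 `COc1ccc(F)cc1-c1cccc(-c2nn(CCO)c(=O)o2)c1` keeps the core of compound 2 and differs only at the chain end: hydrogen in place of oxan-2-yl on an oxygen on a saturated carbon. No measured step covers a hydroxy terminus; the one step shown concerns exchanging the chain terminus and was modest. A step of similar or smaller size in either direction is therefore expected, a number 5 percentage points higher from compound 2 to compound 3 (within the scatter). Compound 3 is estimated at 70%, between 50% and 88%.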

Compound 3, a percentage reported as inhibition, in the whole organism at one dose (the size of the read-out at that dose, not a potency): 75%
Compound 3: middle estimate off by 5 percentage points, on the low side; the range from low to high includes it.
By their numbers in this assay, from the lowest: compounds 2, 3 and 1 (each within the scatter of the next, the first and the last beyond it).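

In this assay, hydrogen in place of oxan-2-yl on the oxygen gives no step beyond the scatter (a number 10 percentage points higher from compound 2 to compound 3 (within the scatter)). The hydroxy end is likewise not separable from the cyanomethyl end (a number 10 percentage points lower from compound 1 to compound 3 (within the scatter)), so it sits within the scatter of both other chain ends, although those two lie apart beyond it. Nothing available explains this behaviour at the chain end.

Still open, as far as these compounds go, is how an amine or a carboxylic acid at the chain end would read in this assay. A longer chain ending in hydroxy also remains an open case.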